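This account rests on a few compounds, and the source may have more. Where it says the series, first, only, none or still open, it means among the compounds named here.

Going by the values given here, compound 2 `CCn1cc(C(=O)Nc2ccc(C)c([N+](=O)[O-])c2)c(=O)c2cc(F)c(N3CCNC(C)C3)c(F)c21` carries a 4-methyl-3-nitrophenyl group on the amide-type nitrogen; in a functional assay on HCT-116 cells (Homo sapiens) for cytotoxicity, read by MTT assay (on this read-out higher numbers stand for weaker inhibition and lower numbers for stronger inhibition), compound 2 gives 11800 nM, the higher of the two numbers measured so far. Among the compounds with values here, its only measured neighbour is compound 1 `CCn1cc(C(=O)Nc2ccccc2N)c(=O)c2cc(F)c(N3CCNC(C)C3)c(F)c21`, which in this assay gives 2700 nM; the step of a 4.4-fold higher number from compound 1 to compound 2 (0.64 log units; beyond the scatter) is the single measured change in this set. Compound 3 `CCn1cc(C(=O)Nc2cc([N+](=O)[O-])ccc2F)c(=O)c2cc(F)c(N3CCNC(C)C3)c(F)c21` differs from compound 2 by 2-fluoro-5-nitrophenyl in place of 4-methyl-3-nitrophenyl on an amide-type nitrogen. Within the data shown here, no measured step bears directly on this change: the one known step exchanges an aminophenyl for a nitrophenyl, whereas compound 3 keeps a nitrophenyl and alters only the remaining substituent of that ring. With nothing to point either way, the expected step of a 1.2-fold lower number from compound 2 to compound 3 (0.07 log units; within the scatter) is small, within the usual scatter. Compound 3 is therefore estimated to give 10000 nM in this assay, with a range from 3500 nM to 30000 nM.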

Compound 3, half-maximal inhibitory concentration: 2600 nM
Estimate against measurement, compound 3: 3.8-fold (0.59 log units) above; the whole stated range lies above it.
By their numbers in this assay, from the lowest: compounds 3 and 1 (each within the scatter of the next); then compound 2.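

In this assay, a nitro group on the phenyl ring does not by itself set the number at this amide-type nitrogen: with a nitrophenyl kept in place, the exchange gives a 4.5-fold lower number from compound 2 to compound 3 (0.66 log units; beyond the scatter). The step of a 1.0-fold lower number from compound 1 to compound 3 (0.02 log units; within the scatter) means that 2-fluoro-5-nitrophenyl and 2-aminophenyl cannot be told apart here, so among these three groups only the 4-methyl-3-nitrophenyl of compound 2 stands apart. Nothing available gives a reason for this difference.

The two nitrophenyl groups differ in both the second substituent and the place of the nitro group, so the compounds shown do not separate the part played by the methyl, the fluorine or the nitro placement. They also leave open how an unsubstituted phenyl, or a phenyl carrying a methoxy group or a carboxylic acid, would read at this nitrogen.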